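The source may hold more compounds than are shown below. What is called first, only, known or untested is meant among the compounds shown, and "the series" means these compounds.

In an ADME assay on MDCK-II cells (Canis lupus familiaris) for permeability (on this read-out lower numbers stand for lower permeability and higher numbers for higher permeability), compound 1 (`CC(C)Oc1cc(Oc2ccc(S(C)(=O)=O)cc2)cc(-c2cccc(=O)[nH]2)c1`) gives 18 10^-6 cm/s, compound 2 (`CC(C)Oc1cc(Oc2ccc(S(C)(=O)=O)cc2)cc(-c2nccc(=O)[nH]2)c1`) gives 24 10^-6 cm/s and compound 3 (`CC(C)Oc1cc(Oc2cnc(C(=O)N(C)C)cn2)cc(-c2nccc(=O)[nH]2)c1`) gives 16 10^-6 cm/s, so compound 3 sits within the scatter of the other two. The next structure, compound 4 (`COC[C@H](C)Oc1cc(Oc2cnc(C(=O)N(C)C)cn2)cc(-c2nccc(=O)[nH]2)c1`), differs from compound 3 by methoxy in place of hydrogen on a saturated chain carbon, two bonds along the chain from an oxygen on an aromatic ring, turning isopropoxy into 1-(methoxymethyl)ethoxy. For the measured compounds named here, the one measured step, a 1.3-fold higher number from compound 1 to compound 2 (0.12 log units; within the scatter), leaves this chain untouched, so it offers only a weak guide. Going by the values given here, no measured pair varies the chain. A small move towards lower numbers in this assay is expected, not clearly beyond the scatter. The expected change is a 1.2-fold lower number from compound 3 to compound 4 (0.09 log units; within the scatter). For compound 4 the estimate is 13 10^-6 cm/s, with an expected range from 7 10^-6 cm/s to 24 10^-6 cm/s.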

Compound 4, apparent permeability in the MDCK-II assay: 2.2 10^-6 cm/s
Beside the measured number, compound 4's estimate is 5.9-fold (0.77 log units) above it; measured number outside the range, below it.
By their numbers in the MDCK-II assay, from the lowest: compound 4; then compounds 3, 1 and 2 (each within the scatter of the next).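

At this chain position, the change from isopropoxy to 1-(methoxymethyl)ethoxy is not neutral in the MDCK-II assay: it gives a 7.3-fold lower number from compound 3 to compound 4 (0.86 log units; beyond the scatter). Compound 1, compound 2 and compound 3 all carry isopropoxy and lie within the scatter of one another, leaving this position untested. In a physicochemical assay for lipophilicity, using the shake flask method (a higher number here means a more lipophilic compound, a lower number a more polar compound), compound 3 gives 1.34 and compound 4 gives 0.81. The lower permeability comes with a lower distribution coefficient, although a single pair cannot link the two: the measured distribution coefficient of compound 3, 1.34, and of compound 4, 0.81, a number 0.53 log units lower (beyond the scatter)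

From the compounds shown here alone, whether an ethyl group on the same chain carbon, with no oxygen, would give a step of similar size remains open. So does whether the step carries over to the core of compound 1.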